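Cyclohexyl for Isopropyl on the Amide of Compound 2

The compounds below may be only part of what the source reports. "The series", "measured", "known", "first", "only" and "open" are said of these compounds alone.

Compound 1 `COC(=O)/C=C/c1cccc(N(Cc2ccc(/C=C/c3scnc3C)cc2)C(=O)C(C)C)c1` gives 228 nM in an assay on isolated protein with Bile acid receptor (Homo sapiens) as the target; on this read-out lower numbers stand for an effect already at smaller amounts and higher numbers for an effect only at larger amounts of compound.
Compound 2 `COC(=O)/C=C/c1cccc(N(Cc2ccc(-c3cc(Cl)ccc3OC)cc2)C(=O)C(C)C)c1` gives 226 nM in this assay.

The two measured compounds share a core and differ only in the group carried on the aromatic carbon; the step of a 1.0-fold lower number from compound 1 to compound 2 (0.00 log units; within the scatter) shows that this exchange left the read-out essentially unchanged. Compound 2 therefore stands at a number that cannot be told apart from that of compound 1 within the usual scatter.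

Compound 3 `COC(=O)/C=C/c1cccc(N(Cc2ccc(-c3cc(Cl)ccc3OC)cc2)C(=O)C2CCCCC2)c1` is the next member. It differs from compound 2 at the amide carbonyl: cyclohexyl in place of isopropyl on a carbonyl carbon. Among the compounds with values here, none of the measured steps touches this part of the molecule; the only step recorded concerns the aromatic substituent, and it was flat. Within the data shown here, there is thus no direct precedent for the size of a change at the carbonyl carbon. With the core held constant and no evidence of sensitivity elsewhere, a modest outcome is expected for this assay, and compound 3 is estimated to give 200 nM (range 70 nM to 600 nM), a step of a 1.1-fold lower number from compound 2 to compound 3 (0.05 log units; within the scatter) that is expected to stay near the scatter.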

Compound 3, half-maximal effective concentration: 233 nM
The estimate for compound 3 lay 1.2-fold (0.07 log units) below the measured number; the measured number falls inside the stated range.
By their numbers in this assay, from the lowest: compounds 2, 1 and 3 (each within the scatter of the next).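

In this assay, the carbonyl carbon of the amide now has a measured step of its own, and the exchange there gives a 1.0-fold higher number from compound 2 to compound 3 (0.01 log units; within the scatter). Cyclohexyl, with 6 heavy atoms and a six-membered non-aromatic ring of carbon only, enters where isopropyl, with 3 heavy atoms and no ring, left, yet this larger difference in the group does not carry the read-out beyond the scatter. Nothing measured in this set accounts for that result, and the flat step is reported here as an observation alone.

The compounds shown leave open whether the carbonyl carbon would stay this flat with a group of another kind, such as an amine, a carboxylic acid or a phenyl ring, in place of cyclohexyl. They also leave open whether a longer chain at this carbon would stay within the scatter of compound 2, and whether the absence of any change would hold with the other aromatic substituent of compound 1 in the molecule.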